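Methyl Moves Around the Anilide Ring of Compound 3

A few compounds are considered here, and "the series" means these few. Any claim that something is new, unique, unknown or untested is made for them only; others in the source may bear on it.

Measured so far, in a functional assay on A549 cells (Homo sapiens) for cytotoxicity, read by MTT assay, with a stated time of 24 h; on this read-out higher numbers stand for weaker inhibition and lower numbers for stronger inhibition:
compound 1 `C=CC1=C(C(=O)Nc2ccccc2OC)C(c2ccc(F)cc2)OC1` gives > 100000 nM, a limit of the assay and not a number.
compound 2 `C=CC1=C(C(=O)NC2CCCCC2)C(c2ccc(OC)cc2)OC1` gives > 100000 nM, again a limit.
compound 3 `C=CC1=C(C(=O)Nc2ccc(C)cc2)C(c2ccc(F)cc2)OC1` gives > 100000 nM, also a limit.

Compound 3 thus stands at the limit of this assay, and the same holds for the other two measured compounds, as the limit of > 100000 nM in this assay, at which 3 of the 3 values shown sit, states. No measured compound has a real number, so the ranking among them cannot be read; none is stronger or weaker than another on what is shown.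

Among the compounds with values here, the single measured step that touches compound 3 is a step that the two limits leave unreadable from compound 1 to compound 3, and its size is not readable, since both ends are limits.

Compound 4 `C=CC1=C(C(=O)Nc2cccc(C)c2)C(c2ccc(F)cc2)OC1` is the next compound. It differs from compound 3 by 3-methylphenyl in place of 4-methylphenyl on an amide-type nitrogen, keeping the same atoms joined differently.

Within the data shown here, the one measured step bearing on this change, the one from compound 1 to compound 3, gives no size and no direction, so there is no measured basis for expecting any step in this assay beyond the scatter. Compound 4 is therefore expected to stay where compound 3 stands, most likely again at the limit; the estimate is 200000 nM, between 80000 nM and 1000000 nM, and the step it implies, a step that the limit leaves unreadable from compound 3 to compound 4, is expected to be nothing beyond the scatter.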

Compound 4, half-maximal inhibitory concentration: > 100000 nM
Compound 4: a limit, no number (the forecaster's own chance of this, stated with the estimate: 85%); the middle value lies beyond the limit too.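

In this assay compound 4 gives > 100000 nM, a limit and not a number. The steps to compound 4 from compound 3 and from compound 1 cannot be read, as both ends of each are limits. The compounds shown leave open whether any change to the shared core gives a real number in this assay.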